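This account rests on a few compounds, and the source may have more. Where it says the series, first, only, none or still open, it means among the compounds named here.

Compound 1 `COc1ccc(-c2c3ccc4ccccc4c3nc3c2c(C)nc2c4ccccc4ccc32)cc1` gives 66400 nM in a functional assay on AGS cells (Homo sapiens) for cytotoxicity, read by MTT assay, with a stated time of 48 h; on this read-out higher numbers stand for weaker inhibition and lower numbers for stronger inhibition.
Compound 2 `Cc1nc2c3ccccc3ccc2c2nc3c(ccc4ccccc43)c(-c3cccc4ccccc34)c12` gives 12100 nM in this assay.
Compound 3 `Cc1nc2c3ccccc3ccc2c2nc3c(ccc4ccccc43)c(-c3ccccc3N)c12` gives 12100 nM in this assay.

Among these three numbers, compound 1 stands highest; a 5.5-fold lower number from compound 1 to compound 2 (0.74 log units; beyond the scatter) and a 5.5-fold lower number from compound 1 to compound 3 (0.74 log units; beyond the scatter) are both beyond the scatter, while compounds 2 and 3 sit at the same number. Compound 4 `Cc1nc2c3ccccc3ccc2c2nc3c(ccc4ccccc43)c(-c3ccc(O)cc3)c12` differs from compound 1 by hydrogen in place of methyl on an oxygen on an aromatic ring. The two measured steps that start from compound 1 both swap out the whole 4-methoxyphenyl for a different ring, and each gives a modest drop in the number. Neither touches only the methyl on the oxygen, so they bear on the step to compound 4 only loosely: they show that changing this ring can move the number by a modest amount, but not that removing a methyl alone will. A small to modest decrease, or no change beyond the scatter, is therefore expected in this assay. Compound 4 is estimated at 35000 nM, with a range from 12000 nM to 90000 nM, which means an expected step of a 1.9-fold lower number from compound 1 to compound 4 (0.28 log units; within the scatter).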

Compound 4, half-maximal inhibitory concentration: 14200 nM
For compound 4 the middle estimate is 2.5-fold (0.39 log units) above the measured one, within the range that was stated.
By their numbers in this assay, from the lowest: compounds 2, 3 and 4 (each within the scatter of the next); then compound 1.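

In this assay, removing only the methyl on the oxygen gives a 4.7-fold lower number from compound 1 to compound 4 (0.67 log units; beyond the scatter), so the earlier drops did not need a whole new ring: this single small edit is enough to produce a modest step. The 4-hydroxyphenyl compound also sits level with the two other ring swaps, with a 1.2-fold higher number from compound 3 to compound 4 (0.07 log units; within the scatter) and a 1.2-fold higher number from compound 2 to compound 4 (0.07 log units; within the scatter), so among these four compounds only compound 1, with its 4-methoxyphenyl, stands apart. Nothing available here explains why losing the methyl has this effect.

Still open, as far as these compounds go, is whether a longer chain on the same oxygen, such as ethyl, would behave like the methyl or like the hydrogen. From the compounds shown here alone, it is also open whether an amine or a carboxylic acid in place of the hydroxy would stay level with compound 4.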